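The source may hold more compounds than are shown below. What is called first, only, known or untested is meant among the compounds shown, and "the series" means these compounds.

Measured so far:
- compound 1 `CC1(C)[C@@H]2CC[C@@]1(CS(=O)(=O)N1CCN(c3ncccc3C(F)(F)F)CC1)C(=O)C2`: in a functional assay on CHO-K1 cells for antagonist activity at C-X-C chemokine receptor type 3 (Homo sapiens), read by FLIPR and calcium flux (on this read-out higher numbers stand for weaker inhibition and lower numbers for stronger inhibition), compound 1 gives > 31600 nM, which is a limit of the assay.
- compound 2 `Cc1ccc(N2CCN(S(=O)(=O)C[C@]34CC[C@H](CC3=O)C4(C)C)CC2)nc1`: in this assay compound 2 gives > 31600 nM, which is again a limit.

Compound 2 therefore stands at the edge of what this assay can report, with no number of its own. The single comparison shown, a step that the two limits leave unreadable from compound 1 to compound 2, is unreadable, as both ends of it sit at the limit of > 31600 nM in this assay, at which 2 of the 2 values shown sit. Nothing else in the series is measured.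

Compound 3 `CC(=O)c1ccc(N2CCN(S(=O)(=O)C[C@]34CC[C@H](CC3=O)C4(C)C)CC2)nc1` is the next member to be run. The change from compound 2 is acetyl in place of methyl on an aromatic carbon.

No measured step in this assay bears on that change in a readable way, so no direction and no size of step can be drawn from the shown data. The expectation for compound 3 rests only on the fact that compound 2 sits at the limit: compound 3 is estimated at 31600 nM, within 5000 nM to 100000 nM. The implied step a number no higher from compound 2 to compound 3 (the limit leaves the size open) is an expectation of no change beyond the scatter, with a clear chance that compound 3 also returns only a limit.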

Compound 3, half-maximal inhibitory concentration: > 31600 nM
Compound 3: a limit, no number (the forecaster's own chance of this, stated with the estimate: 75%); the middle value lies on the limit itself.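

In this assay compound 3 gives > 31600 nM, which is again a limit. No step among compound 1, compound 2 and compound 3 can be read, as all three end at the same limit: the limit of > 31600 nM in this assay, at which 3 of the 3 values shown sit.

The compounds shown leave open whether any group on the pyridin-2-yl ring of this series gives a readable value in this assay.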